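The source may report more compounds than this note shows. Statements on the series, on what has been measured and on what is new or still open speak of the compounds shown alone.

Measured compounds, with their values in an assay for binding affinity to dual specificity mitogen-activated protein kinase kinase 4 (Homo sapiens), read by KINOMEscan, tested at 100 nM; a lower number here means a stronger effect, a higher number a weaker effect of the compound at the concentration tested:
compound 1 `CCCS(=O)(=O)Nc1ccc(F)c(C(=O)c2n[nH]c3ncc(-c4ccccc4Cl)cc23)c1F` gives 9.3%
compound 2 `CCCS(=O)(=O)Nc1ccc(F)c(C(=O)c2n[nH]c3ncc(-c4cccc(F)c4)cc23)c1F` gives 8.2%
compound 3 `CCCS(=O)(=O)Nc1ccc(F)c(C(=O)c2n[nH]c3ncc(-c4cccc(N(C)C)c4)cc23)c1F` gives 26%

Compound 1 stands second highest of the three numbers in this assay; its nearest neighbour is compound 2, with a number 1.1 percentage points lower from compound 1 to compound 2 (within the scatter), and its furthest is compound 3, with a number 16.7 percentage points higher from compound 1 to compound 3 (beyond the scatter).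

Compound 4 `CCCS(=O)(=O)Nc1ccc(F)c(C(=O)c2n[nH]c3ncc(-c4ccc(N(C)C)cc4)cc23)c1F` is not yet measured. Against compound 1 the change is 4-(dimethylamino)phenyl in place of 2-chlorophenyl on an aromatic carbon. Within the data shown here, two measured steps bear on it. The step of a number 16.7 percentage points higher from compound 1 to compound 3 (beyond the scatter) introduces the dimethylamino group at a different position of the phenyl ring than in compound 4, and the step of a number 17.8 percentage points higher from compound 2 to compound 3 (beyond the scatter) shows the same group in place of fluoro. Among the measured compounds shown here, both move the number upward by a modest, beyond-scatter amount, so a step of similar size and direction is expected for compound 4, with the caveat that no compound with a 4-(dimethylamino)phenyl group has been measured. The expected step is a number 15.7 percentage points higher from compound 1 to compound 4 (beyond the scatter). The estimate for compound 4 in this assay is 25%, with a range from 10% to 45%.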

Compound 4, a percentage reported as activity, at one concentration (the size of the read-out at that concentration, not a potency): 2.5%
Compound 4: the middle estimate sits 22.5 percentage points above what was measured, and the stated range ends above it.
By their numbers in this assay, from the lowest: compounds 4, 2 and 1 (each within the scatter of the next); then compound 3.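

In this assay, a dimethylamino group on this phenyl ring does not bring a higher number in every placement: a number 23.5 percentage points lower from compound 3 to compound 4 (beyond the scatter) separates the 3-(dimethylamino)phenyl and 4-(dimethylamino)phenyl groups. The 4-(dimethylamino)phenyl group also stays level with the two halogen-bearing aryl groups, with a number 6.8 percentage points lower from compound 1 to compound 4 (within the scatter) and a number 5.7 percentage points lower from compound 2 to compound 4 (within the scatter) both printed as within the scatter, so among these four compounds compound 3 alone stands apart. Nothing measured here accounts for the gap between the two dimethylamino placements.

Still open, on these data alone, is whether the same gap appears with a 3-methoxyphenyl and 4-methoxyphenyl pair, or with a 3-morpholinophenyl and 4-morpholinophenyl pair. The compounds shown also leave open how a 2-(dimethylamino)phenyl group or a 4-carboxyphenyl group would read at this position.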